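A few compounds are considered here, and "the series" means these few. Any claim that something is new, unique, unknown or untested is made for them only; others in the source may bear on it.

Compound 1 `CC(C(=O)NCc1ccc(C(F)(F)F)nc1)c1ccc(NS(C)(=O)=O)c(F)c1` carries only a hydrogen at the aromatic carbon in question, and in a functional assay on CHO-K1 cells for antagonist activity at transient receptor potential cation channel subfamily V member 1 (Homo sapiens), read by FLIPR (on this read-out lower numbers stand for stronger inhibition and higher numbers for weaker inhibition), compound 1 is reported as "not active" (no number reported), so no single number places it among the others. Compound 2 `CC(C(=O)NCc1ccc(C(F)(F)F)nc1Nc1ccccc1)c1ccc(NS(C)(=O)=O)c(F)c1` is substituted where compound 1 has that hydrogen, and in this assay compound 2 gives 1400 nM; compound 3 `Cc1ccc(Nc2nc(C(F)(F)F)ccc2CNC(=O)C(C)c2ccc(NS(C)(=O)=O)c(F)c2)cc1C` gives 1160 nM. The step of a 1.2-fold lower number from compound 2 to compound 3 (0.08 log units; within the scatter) bears on the case only indirectly, showing that two different groups there give similar numbers. Compound 4 `CC(C(=O)NCc1ccc(C(F)(F)F)nc1N1CCCCCC1)c1ccc(NS(C)(=O)=O)c(F)c1` differs from compound 1 by azepan-1-yl in place of hydrogen on an aromatic carbon. Since substitution there in compound 2 yields a measurable 1400 nM, compound 4 is expected to give a measurable number in this assay as well. Compound 4 is estimated at 1500 nM, within 400 nM to 6000 nM.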

Compound 4, half-maximal inhibitory concentration: 25.1 nM
Beside the measured number, compound 4's estimate is 60-fold (1.78 log units) above it; the whole stated range lies above it.
By their numbers in this assay, from the lowest: compound 4; then compounds 3 and 2 (each within the scatter of the next).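

In this assay the choice of group on this aromatic carbon matters far more than compound 2 and compound 3 alone suggested: azepan-1-yl gives a 56-fold lower number from compound 2 to compound 4 (1.75 log units; beyond the scatter) and a 46-fold lower number from compound 3 to compound 4 (1.66 log units; beyond the scatter). The close numbers of the anilino and (3,4-dimethylphenyl)amino compounds therefore do not mean that every substituent here reads alike. No measurement at hand accounts for this difference. Still open, from the compounds shown here alone, is whether piperidin-1-yl, morpholin-4-yl or an open-chain diethylamino group on this carbon would match azepan-1-yl. Also open, going by these compounds, is whether the low number of compound 4 depends on the trifluoromethyl group.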